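Pyrazole Substitution on the Acetamide Arm of a Chemokine Antagonist

The compounds below may be only part of what the source reports. "The series", "measured", "known", "first", "only" and "open" are said of these compounds alone.

Compound 1, `C[C@@H]1CN(c2sc(C(F)(F)F)nc2-c2nc3ccccc3[nH]2)CCN1C(=O)Cn1cccn1`: in a functional assay on Venous blood for antagonist activity at C-X-C chemokine receptor type 3 (Homo sapiens), read by flow cytometry, with a stated time of 30 min, in the presence of a further agent that is not named here (on this read-out higher numbers stand for weaker inhibition and lower numbers for stronger inhibition), compound 1 gives 191 nM.
Compound 2, `C[C@@H]1CN(c2sc(C(F)(F)F)nc2-c2nc3ccccc3[nH]2)CCN1C(=O)Cn1cnc2cccnc21`: in this assay compound 2 gives 70 nM.

Among the measured compounds shown here, compound 2 holds the lower of the two numbers measured so far, and the gap to compound 1 is beyond the scatter: a 2.7-fold lower number from compound 1 to compound 2 (0.44 log units; beyond the scatter). For the measured compounds named here, that single step is the only measured change on the acetamide arm, and it shows that replacing the smaller five-membered ring with a fused aromatic bicycle strengthened inhibition modestly.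

Compound 3, `C[C@@H]1CN(c2sc(C(F)(F)F)nc2-c2nc3ccccc3[nH]2)CCN1C(=O)Cn1cc(C2CCN(C)CC2)cn1`, carries a different change on the same carbon: a group of 12 heavy atoms (9 carbon, 3 nitrogen; one five-membered aromatic ring with 2 hetero atoms, one six-membered non-aromatic ring with 1 hetero atom) in place of a group of 9 heavy atoms (6 carbon, 3 nitrogen; one five-membered aromatic ring with 2 hetero atoms, one six-membered aromatic ring with 1 hetero atom), on a saturated chain carbon bound to a carbonyl carbon. On these data alone, the entering group keeps the five-membered aromatic ring of compound 1 but adds a six-membered non-aromatic ring with one hetero atom, so the step from compound 1 to compound 2 bears on it only indirectly; whether added size without a second aromatic ring helps in this assay is untested. The step of a 1.4-fold higher number from compound 2 to compound 3 (0.15 log units; within the scatter) is therefore expected to be small, plausibly within the scatter, with a lean toward a slightly higher number. Compound 3 is estimated at 100 nM, with a range of 35 nM to 300 nM.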

Compound 3, half-maximal inhibitory concentration: 1690 nM
For compound 3 the middle estimate is 17-fold (1.23 log units) below the measured one; measured number above the stated range.
By their numbers in this assay, from the lowest: compound 2; then compound 1; then compound 3.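

Substitution on the pyrazole itself now has a measured outcome: with 1-methylpiperidin-4-yl in place of hydrogen on an aromatic carbon, this assay shows an 8.8-fold higher number from compound 1 to compound 3 (0.95 log units; beyond the scatter), so this addition goes with weaker inhibition. Set against the group with the six-membered aromatic ring, the entering group gives a 24-fold higher number from compound 2 to compound 3 (1.38 log units; beyond the scatter), which shows that a change on the saturated chain carbon bound to a carbonyl carbon can weaken inhibition as well as strengthen it. Across the three compounds, a larger group does not by itself bring a lower number, and nothing available explains the loss.

The compounds shown do not separate the piperidine ring from its methyl group, so a piperidin-4-yl group with hydrogen on its nitrogen, or a cyclohexyl group on the same pyrazole carbon, would be needed to tell whether the ring nitrogen or the ring itself goes with the higher number. On these data alone, it also remains open whether a smaller group on that pyrazole carbon, such as methyl or a methoxy group, would keep the number of compound 1 or move it.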